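Bromo for butoxy on the six-membered aromatic ring: compound 4

This account rests on a few compounds, and the source may have more. Where it says the series, first, only, none or still open, it means among the compounds named here.

Compound 1, `CCOC(=O)c1c(-c2cccc(-c3ccccc3)c2)[nH]c2cc(OC)ccc2c1=O`, carries a phenyl on the six-membered aromatic ring of carbon only; compound 2, `CCOC(=O)c1c(-c2cccc(OC)c2)[nH]c2cc(OC)ccc2c1=O`, carries a methoxy there, and compound 3, `CCCCOc1cccc(-c2[nH]c3cc(OC)ccc3c(=O)c2C(=O)OCC)c1`, a butoxy. In an ADME assay on HEK293 cells (Homo sapiens) for cytotoxicity, read by luminescence, with a stated time of 72 h (on this read-out lower numbers stand for an effect already at smaller amounts and higher numbers for an effect only at larger amounts of compound), compound 1 gives > 22000 nM, which is a limit of the assay and not a number. Compound 2 gives > 22000 nM, likewise a limit. Compound 3 gives > 22000 nM, again a limit. Compound 3 therefore stands where every measured member of the series stands, with the limit of > 22000 nM in this assay, at which 3 of the 3 values shown sit. The steps a step that the two limits leave unreadable from compound 1 to compound 2, a step that the two limits leave unreadable from compound 1 to compound 3 and a step that the two limits leave unreadable from compound 2 to compound 3 are thus of unreadable size, and no effect of the varied group can be read off from them.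

Compound 4, `CCOC(=O)c1c(-c2cccc(Br)c2)[nH]c2cc(OC)ccc2c1=O`, differs from compound 3 as follows: bromo in place of butoxy on an aromatic carbon. Going by the values given here, none of the measured steps offers a readable size to carry over, since all three sit at the limit; they bear on the present step only in that the group at this place has so far produced nothing within the range of this assay. With compound 4 most likely again at the limit, the step that the limit leaves unreadable from compound 3 to compound 4 is expected to be none beyond the scatter. For compound 4 the estimate in this assay is 30000 nM, with a range from 12000 nM to 100000 nM.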

Compound 4, half-maximal effective concentration: > 22000 nM
Compound 4 ended at the assay's limit (the forecaster's own chance of this, stated with the estimate: 80%); the middle value lies beyond the limit too.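

No new step can be read for compound 4 against compound 1, compound 2 or compound 3 in this assay, since all four give only a limit of the assay and not a number: the limit of > 22000 nM in this assay, at which 4 of the 4 values shown sit.

The compounds shown leave open whether any group at this place gives a readable value in this assay, and how large a step between such groups would be.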